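The source may report more compounds than this note shows. Statements on the series, on what has been measured and on what is new or still open speak of the compounds shown alone.

Measured in an assay on cell membranes for binding affinity to adenosine receptor A1 (Cavia porcellus), read by radioligand binding; a higher number here means a weaker inhibitor, a lower number a stronger inhibitor:
compound 1 `CCCn1c(=O)c2nc([C@H]3CC4C=CC3C4)[nH]c2n(CCC)c1=O` — 3.4 nM
compound 2 `CC1(Nc2ncnc3c2ncn3C2O[C@H](CO)[C@@H](O)[C@H]2O)CCCCC1` — 70 nM
compound 3 `CCCn1c(=O)c2nc(-c3cc4ccccc4s3)[nH]c2n(CCC)c1=O` — > 100000 nM

Compound 1 gives the lowest number among the values that are numbers; compound 2 sits well above it, a gap that lies beyond the usual scatter. For compound 3 the result is a limit of the assay and not a number, as recorded in the limit of > 100000 nM in this assay, at which 1 of the 3 values shown sits. Going by the values given here, compounds 1 and 3 share the same core and differ only in the group carried on it, but no counted step between them is given, so only the two readings themselves can be set side by side.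

The next compound, compound 4 `CCCn1c(=O)c2nc(C(C)(O)CC)[nH]c2n(CCC)c1=O`, keeps the core of compound 1 and changes the substituent: a group of 5 heavy atoms (4 carbon, 1 oxygen; no ring) in place of a group of 7 heavy atoms (7 carbon; 2 five-membered non-aromatic rings of carbon only), on an aromatic carbon. The 1-hydroxy-1-methylpropyl group that enters brings one hydrogen-bond donor and one acceptor where the leaving group had none.

Among the compounds with values here, with no measured step of this kind available, the expectation is a weakening in this assay, a step from compound 1 to compound 4 of an 18-fold higher number from compound 1 to compound 4 (1.25 log units; beyond the scatter), clearly beyond the scatter. For compound 4 the estimated value is 60 nM, with a range of 15 nM to 300 nM.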

Compound 4, inhibition constant: 240 nM
Compound 4: middle estimate off by 4.0-fold (0.60 log units), on the low side; the measured number falls inside the stated range.
By their numbers in this assay, from the lowest: compound 1; then compound 2; then compound 4. At a limit, above all of these: compound 3.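

In this assay, going by these compounds alone, putting the open-chain 1-hydroxy-1-methylpropyl group in place of the group of 7 heavy atoms with its 2 five-membered non-aromatic rings gives a 71-fold higher number from compound 1 to compound 4 (1.85 log units; beyond the scatter), the first counted step at this position on the shared core, an aromatic carbon between two ring nitrogen atoms. The step is large, yet compound 4 still gives a number, 240 nM, so a group with no ring that carries a hydrogen-bond donor and a hydrogen-bond acceptor can sit at this position and still return a reading. Compound 3, on the same core, stands at a limit of the assay and not a number, recorded as > 100000 nM.

Nothing measured here accounts for the size of the step, and this single change cannot separate the loss of the rings from the entry of the hydroxyl group. Still open, going by these compounds, is where an open-chain group without the hydroxyl group, such as a longer alkyl chain, or a group bearing an amine or a carboxylic acid at this position, would fall relative to compound 1 and compound 4.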